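The source may report more compounds than this note shows. Statements on the series, on what has been measured and on what is new or still open speak of the compounds shown alone.

In a functional assay on the whole organism for agonist activity, with Mus musculus as the target (a higher number here means that more compound is needed for the effect, a lower number that less compound is needed), compound 2 `CC(=O)N(C)CC#CCn1ccnc1` gives 0.97 mg/kg as the lowest of three numbers, while compound 1 `CC(=O)N(C)C(C)C#CCn1ccnc1` at 2 mg/kg and compound 3 `CC(=O)N(C)CC#CCn1cncc1C` at 5.4 mg/kg both lie higher. Compound 4 `CCOC(=O)N(C)CC#CCn1ccnc1` has ethoxy in place of methyl on a carbonyl carbon. Going by the values given here, no measured step changes this group, so the two measured steps serve only as a guide to size: a 2.1-fold lower number from compound 1 to compound 2 (0.31 log units; beyond the scatter) and a 5.6-fold higher number from compound 2 to compound 3 (0.75 log units; beyond the scatter) are both modest. Both show a higher number with an added methyl, but the direction here remains uncertain. A modest rise in this assay is expected, and the estimated step is a 2.6-fold higher number from compound 2 to compound 4 (0.41 log units; beyond the scatter) in this series. For compound 4 the estimated value is 2.5 mg/kg (expected range 0.6 mg/kg to 10 mg/kg).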

Compound 4, dose for half-maximal effect: > 100 mg/kg
Compound 4 gave a limit, no number; the forecaster's own chance of this, stated with the estimate: 5%; middle value at least 40-fold (1.60 log units) away from the limit.
By their numbers in this assay, from the lowest: compound 2; then compound 1; then compound 3. At a limit, above all of these: compound 4.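

In this assay, going by these compounds alone, the carbonyl carbon whose other neighbour is the amide-type nitrogen responds far more strongly than the earlier steps indicated: ethoxy in place of methyl gives an at least 100-fold higher number from compound 2 to compound 4 (2.01 log units; beyond the scatter), the largest step. Compound 4 gives a limit, not a number: the limit of > 100 mg/kg in this assay, at which 1 of the 4 values shown sits.

Acetyl to ethoxycarbonyl is the only change shown that reaches this limit. The compounds shown leave open whether the oxygen of the ethoxy or its longer chain decides the outcome. A propionyl or a methoxycarbonyl group in place of the acetyl would help separate the two.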